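Shrinking the pendant aryl group on a fused azaaromatic core

This account rests on a few compounds, and the source may have more. Where it says the series, first, only, none or still open, it means among the compounds named here.

Measured compounds:
Compound 1, `Cc1nc2c3ccccc3ccc2c2nc3c(ccc4ccccc43)c(-c3nccnc3N)c12`: 2260 nM
Compound 2, `Cc1nc2c3ccccc3ccc2c2nc3c(ccc4ccccc43)c(-c3cccc4ccccc34)c12`: 12100 nM

In a functional assay on AGS cells (Homo sapiens) for cytotoxicity, read by MTT assay, with a stated time of 48 h (on this read-out lower numbers stand for stronger inhibition and higher numbers for weaker inhibition), compound 2 gives the higher of the two numbers, and it stands apart from compound 1 by a 5.4-fold higher number from compound 1 to compound 2 (0.73 log units; beyond the scatter). Compound 3, `Cc1nc2c3ccccc3ccc2c2nc3c(ccc4ccccc43)c(-c3ccccc3)c12`, has not been measured in this assay. It differs from compound 2 as follows: phenyl in place of naphthalen-1-yl on an aromatic carbon. Within the data shown here, the one measured step, a 5.4-fold higher number from compound 1 to compound 2 (0.73 log units; beyond the scatter), compares an amino-substituted heteroaryl with naphthalen-1-yl and so does not speak directly to the exchange of naphthalen-1-yl for phenyl; it shows only that the group at this position can move the number in this assay by a modest amount. Among the measured compounds shown here, with no measured step that removes a ring at this position, the expectation for compound 3 is a step of a 1.2-fold lower number from compound 2 to compound 3 (0.08 log units; within the scatter) from compound 2, not beyond the scatter. Compound 3 is therefore expected to give about 10000 nM in this assay, within a range of 4000 nM to 30000 nM.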

Compound 3, half-maximal inhibitory concentration: > 80000 nM
Compound 3 ended at the assay's limit (the forecaster's own chance of this, stated with the estimate: 10%); at least 8.0-fold (0.90 log units) between middle value and limit.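

Taking one ring out of the pendant group at this position is not a neutral change in this assay: phenyl in place of naphthalen-1-yl gives an at least 6.6-fold higher number from compound 2 to compound 3 (0.82 log units; beyond the scatter). The value of compound 3 is a limit, not a number: the limit of > 80000 nM in this assay, at which 1 of the 3 values shown sits. Against the heteroaryl group the gap is wider still, at an at least 35-fold higher number from compound 1 to compound 3 (1.54 log units; beyond the scatter), so phenyl gives the weakest result of the three, and ring count alone does not order them, as the single-ring 3-aminopyrazin-2-yl of compound 1 goes against any trend favouring more rings.

The compounds shown leave open whether the amine or the ring nitrogens of 3-aminopyrazin-2-yl account for the lower number of compound 1. From the compounds shown here alone, a phenyl bearing an amine, and a pyrazin-2-yl without one, would separate the two, and how a carboxylic acid on the phenyl of compound 3 would read also remains open.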